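A few compounds are considered here, and "the series" means these few. Any claim that something is new, unique, unknown or untested is made for them only; others in the source may bear on it.

Two compounds built on the same core have been examined in a functional assay on KB cells (Homo sapiens) for cytotoxicity, read by MTT assay, with a stated time of 72 h; on this read-out lower numbers stand for an effect already at smaller amounts and higher numbers for an effect only at larger amounts of compound. Compound 1 has the structure `CCOc1c(-c2occ(C)c2C(=O)O)ccc2c(CC)cccc12`. In this assay compound 1 reaches only a limit of the measurement, > 10 ug/mL. Compound 2 has the structure `CCc1cccc2c(OC)c(-c3occ(C)c3COC)ccc12`. In this assay compound 2 likewise gives only a limit, > 10 ug/mL. For the measured compounds named here, compound 2 therefore stands at the limit of the measurement, the place where every value so far sits, as the limit of > 10 ug/mL in this assay, at which 2 of the 2 values shown sit, shows. Going by the values given here, no pair of measured compounds that differ in a single place is available, so no measured step can be read.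

Compound 3, with the structure `CCOc1c(-c2occ(C)c2COC)ccc2c(CC)cccc12`, has not yet been measured. It differs from compound 2 by methyl in place of hydrogen on a saturated chain carbon bound to an oxygen on an aromatic ring. With both known values being limits, a change of this small size is expected to leave the result within the usual scatter, with no shift beyond it in either direction. The step expected in this assay is a step that the limit leaves unreadable from compound 2 to compound 3. Compound 3 is thus estimated at 15 ug/mL in this assay, within a range from 5 ug/mL to 40 ug/mL.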

Compound 3, concentration for half-maximal effect: > 10 ug/mL
Compound 3 ended at the assay's limit; the forecaster's own chance of this, stated with the estimate: 85%; the middle value does not contradict the limit.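

Compound 3 also gives only a limit in this assay, so neither its step from compound 2 nor its step from compound 1 can be read: the limit of > 10 ug/mL in this assay, at which 3 of the 3 values shown sit.

Going by these compounds, how far each of the three compounds lies from that limit stays open, as does whether exchanging methoxy for ethoxy or carboxy for methoxymethyl changes the cytotoxicity at all.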